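From 3-Fluorophenyl to 2-Chlorophenyl: Expected Seizure Protection

The compounds below may be only part of what the source reports. "The series", "measured", "known", "first", "only" and "open" are said of these compounds alone.

Compound 1 `COc1cccc(N2CCN(C(=O)C(C)N3C(=O)CCC3=O)CC2)c1` gives 50% in a functional assay on the whole organism (strain Swiss) with Mus musculus as the target, in the maximal electroshock model, with a stated time of 0.5 h, at a dose of 300 mg/kg by the intraperitoneal route; a lower number here means a weaker effect, a higher number a stronger effect of the compound at the dose given.
Compound 2 `CC(C(=O)N1CCN(c2ccc(F)cc2)CC1)N1C(=O)CCC1=O` gives 50%.
Compound 3 `CC(C(=O)N1CCN(c2cccc(F)c2)CC1)N1C(=O)CCC1=O` gives 50%.

Compound 3 stands level with compound 1 and compound 2: the steps of no change at the digits printed from compound 1 to compound 2 (within the scatter), no change at the digits printed from compound 1 to compound 3 (within the scatter) and no change at the digits printed from compound 2 to compound 3 (within the scatter) all lie within the scatter. Compound 4 `CC(C(=O)N1CCN(c2ccccc2Cl)CC1)N1C(=O)CCC1=O` differs from compound 3 by 2-chlorophenyl in place of 3-fluorophenyl on an amine nitrogen in a ring. For the measured compounds named here, the step that bears most closely on this is the exchange of one fluorophenyl for another on the same ring nitrogen, which gave no change at the digits printed from compound 2 to compound 3 (within the scatter); no measured step exchanges fluorine for chlorine, so that part of the change is untested. Compound 4 is therefore expected to show no step beyond the scatter, no change at the digits printed from compound 3 to compound 4 (within the scatter), with an estimated 50% between 25% and 75%.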

Compound 4, a percentage reported as activity, at one dose (the size of the read-out at that dose, not a potency): 0%
The estimate for compound 4 lay 50 percentage points above the measured number; the whole stated range lies above it.
By their numbers in this assay, from the lowest: compound 4; then compounds 1, 2 and 3 (each within the scatter of the next).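

In this assay, the group on the ring nitrogen proves able to decide the outcome: exchanges among 3-methoxyphenyl, 4-fluorophenyl and 3-fluorophenyl left the read-out level, whereas 2-chlorophenyl brings a number 50 percentage points lower from compound 3 to compound 4 (beyond the scatter) and a number 50 percentage points lower from compound 2 to compound 4 (beyond the scatter) and also a number 50 percentage points lower from compound 1 to compound 4 (beyond the scatter) at this same place. This position is therefore not indifferent to every substituted phenyl group. No measurement available here accounts for the loss.

The compounds shown leave open whether 2-fluorophenyl or 3-chlorophenyl would stay level with compound 3 or fall with compound 4, so the chlorine and its place on the ring remain unseparated.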